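The compounds below may be only part of what the source reports. "The series", "measured", "known", "first", "only" and "open" are said of these compounds alone.

Compound 1 `O=C(NC1CCC(O)CC1)N1CCC(c2nc(-c3ccc4ccccc4n3)no2)CC1` was tested in a functional assay on Shh Light II cells (Mus musculus) for inhibition, read by a luciferase reporter (on this read-out higher numbers stand for weaker inhibition and lower numbers for stronger inhibition), where compound 1 gives 2700 nM. Of the two numbers in hand this is the higher one, but the nearest neighbour, compound 2 `COc1ccccc1NC(=O)N1CCC(c2noc(-c3ccc4ccccc4n3)n2)CC1`, gives 2400 nM in this assay, and that gap sits within the scatter of repeated measurements, so the two compounds cannot be told apart. Among the measured compounds shown here, no pair of measured compounds differs in a single place, and so no measured step is available to lean on. Compound 3 `O=C(NC1CCOCC1)N1CCC(c2nc(-c3ccc4ccccc4n3)no2)CC1` has not yet been measured in this assay. It differs from compound 1 in one place: oxan-4-yl in place of 4-hydroxycyclohexyl on an amide-type nitrogen. Without a measured step to guide it, the expected step in this assay is a 1.3-fold higher number from compound 1 to compound 3 (0.11 log units; within the scatter), a shift that may well stay inside the scatter. Compound 3 is therefore estimated at 3500 nM, with a range from 1200 nM to 10000 nM.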

Compound 3, half-maximal inhibitory concentration: 480 nM
Beside the measured number, compound 3's estimate is 7.3-fold (0.86 log units) above it, and the stated range ends above it.
By their numbers in this assay, from the lowest: compound 3; then compounds 2 and 1 (each within the scatter of the next).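

The group on the amide-type nitrogen of this series is therefore not a silent position in this assay: oxan-4-yl in place of 4-hydroxycyclohexyl gives a clear gain in inhibition (a 5.6-fold lower number from compound 1 to compound 3 (0.75 log units; beyond the scatter)), a step beyond the scatter. The change replaces a carbon-only ring carrying a hydrogen-bond donor with a ring that holds one hetero atom and has no donor, while the count of hydrogen-bond acceptors stays the same, so stronger inhibition here does not require a donor on this group. Nothing in the data explains why the number falls.

This single step cannot separate the loss of the hydroxy group from the oxygen's move into the ring. A plain cyclohexyl group or a piperidin-4-yl amine at the same nitrogen would bear on that question, and neither is among the compounds shown.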